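Removing a Methoxy Group: Expected Effect on Cell Growth

The source may report more compounds than this note shows. Statements on the series, on what has been measured and on what is new or still open speak of the compounds shown alone.

Compound 1 `COc1ccc(-c2ccc(-c3ccc(C(=N)N)o3)o2)cc1` was tested in a functional assay on A549 cells (Homo sapiens) for inhibition, read by sulforhodamine B assay, with a stated time of 48 h (on this read-out higher numbers stand for weaker inhibition of growth and lower numbers for stronger inhibition of growth), where compound 1 gives 1490 nM. Among the measured compounds shown here, that is the lowest of the two numbers measured so far; the other compound, compound 2 `COc1cc(OC)cc(-c2ccc(-c3ccc(C(=N)N)o3)o2)c1`, gives 3780 nM in this assay, a gap beyond the usual scatter. Compound 3 `N=C(N)c1ccc(-c2ccc(-c3ccccc3)o2)o1` has not yet been measured. From compound 1 it differs by hydrogen in place of methoxy on an aromatic carbon. For the measured compounds named here, no measured pair shows this particular change, so the step is expected to stay within the scatter, with no clear direction. Compound 3 is therefore expected to give about 1500 nM in this assay, with a range from 500 nM to 4500 nM. The expected step is a 1.0-fold higher number from compound 1 to compound 3 (0.00 log units; within the scatter).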

Compound 3, concentration for 50% growth inhibition: 3550 nM
Beside the measured number, compound 3's estimate is 2.4-fold (0.37 log units) below it, and the stated range covers the measured number.
By their numbers in this assay, from the lowest: compound 1; then compounds 3 and 2 (each within the scatter of the next).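

Among the compounds shown here, this is the only measured pair for this change: on the six-membered aromatic ring, para to a large group, hydrogen in place of methoxy gives a 2.4-fold higher number from compound 1 to compound 3 (0.38 log units; beyond the scatter) in this assay. At this position, then, the methoxy group makes a real though modest difference, with growth inhibited less strongly once it is gone. Nothing measured here gives a reason for this step.

As far as these compounds go, whether an ethoxy group, a fluorine atom or an amine at the same position would match compound 1 remains open. A single pair also cannot show whether this change would give a similar step elsewhere on the ring.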